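From Fluoro to Nitro on the Same Aryl Ring

The compounds below may be only part of what the source reports. "The series", "measured", "known", "first", "only" and "open" are said of these compounds alone.

Three compounds have so far been measured in a functional assay on HT-29 cells (Homo sapiens) for cytotoxicity, read by MTT assay, with a stated time of 72 h; a lower number here means a stronger inhibitor, a higher number a weaker inhibitor:

Compound 1 `COc1cc2c(Oc3ccc(NC(=O)c4nn(-c5cccc(F)c5)c(=O)c5ccccc45)cc3F)ccnc2cc1OCCCN1CCCC1` gives 460 nM.
Compound 2 `COc1cc2c(Oc3ccc(NC(=O)c4nn(-c5ccccc5Br)c(=O)c5ccccc45)cc3F)ccnc2cc1OCCCN1CCCC1` gives 850 nM.
Compound 3 `COc1cc2c(Oc3ccc(NC(=O)c4nn(-c5ccc(F)cc5)c(=O)c5ccccc45)cc3F)ccnc2cc1OCCCN1CCN(C)CC1` gives 320 nM.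

Compound 3 has the lowest of the three numbers. Compound 1 sits within the scatter of it, so the two cannot be ordered; compound 2 lies beyond the scatter and is the weaker of the pair.

Compound 4 `COc1cc2c(Oc3ccc(NC(=O)c4nn(-c5ccc([N+](=O)[O-])cc5)c(=O)c5ccccc45)cc3F)ccnc2cc1OCCCN1CCN(C)CC1` is the next compound. It differs from compound 3 in one place: nitro in place of fluoro on an aromatic carbon, para to a large group.

For the measured compounds named here, only one measured step bears on this change, and only loosely. The step of a 1.8-fold higher number from compound 1 to compound 2 (0.27 log units; within the scatter) also alters the group on the same aromatic ring, but it swaps one halogen for another at a different spot and stays within the scatter. Going by the values given here, no measured step replaces fluoro by nitro, so there is nothing to show that this swap moves the number strongly.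

The expectation for compound 4 is therefore a step of a 1.3-fold higher number from compound 3 to compound 4 (0.10 log units; within the scatter), not beyond the scatter. Compound 4 is estimated at 400 nM, with a range from 150 nM to 1100 nM.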

Compound 4, half-maximal inhibitory concentration: 2560 nM
For compound 4 the middle estimate is 6.4-fold (0.81 log units) below the measured one; measured number outside the range, above it.
By their numbers in this assay, from the lowest: compounds 3, 1 and 2 (each within the scatter of the next, the first and the last beyond it); then compound 4.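

In this assay, exchanging the 4-fluorophenyl of compound 3 for the 4-nitrophenyl of compound 4 gives (an 8.0-fold higher number from compound 3 to compound 4 (0.90 log units; beyond the scatter)), so the group para to a large group on this aromatic ring can clearly change the number. For the compounds shown here, the only earlier step on this ring, (a 1.8-fold higher number from compound 1 to compound 2 (0.27 log units; within the scatter)), swapped one halogen-bearing ring for another and stayed within the scatter, so it gave no sign that a change on this ring could matter this much. What enters is also a different kind of group rather than another halogen, with three heavy atoms in place of one and two hydrogen-bond acceptors where fluoro has none, yet no measurement here connects either count, or anything else about the swap, to the rise in the number.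

The compounds shown leave open whether this rise is particular to nitro, and an amine, a nitrile or a methoxy group on the same aromatic carbon would help to settle that. On these data alone, it also remains unknown whether the same swap would give a similar step on a compound carrying the side chain of compound 1.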